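A few compounds are considered here, and "the series" means these few. Any claim that something is new, unique, unknown or untested is made for them only; others in the source may bear on it.

Working notes on the series, read in a functional assay on CHO cells for agonist activity at Free fatty acid receptor 1 (Homo sapiens), read by a luciferase reporter; a higher number here means a larger maximal response, a lower number a smaller maximal response. Compound 1 `NC(=O)CCc1ccc(NCc2cccc(Oc3ccccc3)c2)cc1` reaches 68% in this assay. Compound 3 `CC(C)NC(=O)CCc1ccc(NCc2cccc(Oc3ccccc3)c2)cc1` carries isopropyl in place of hydrogen on an amide-type nitrogen relative to compound 1; in this assay compound 3 gives 66%, and the step is a number 2 percentage points lower from compound 1 to compound 3 (within the scatter). Compound 2 `Cc1nc(-c2ccc(C(F)(F)F)cc2)sc1CNc1ccc(CCC(N)=O)cc1` stands on a different core; the difference between the core of compound 2 and the core of compound 1 is not broken down here. In this assay compound 2 gives 88%, the highest of the three numbers, beyond the scatter from both compound 1 and compound 3.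

Compound 4 `Cc1nc(-c2ccc(C(F)(F)F)cc2)sc1CNc1ccc(CCC(=O)NC(C)C)cc1` is still to be measured in this assay. It carries isopropyl in place of hydrogen on an amide-type nitrogen relative to compound 2, the same kind of change as that from compound 1 to compound 3, made at a place described in the same words. For the measured compounds named here, the expected step is a number 2 percentage points lower from compound 2 to compound 4 (within the scatter), because a number 2 percentage points lower from compound 1 to compound 3 (within the scatter) is the only precedent for this change and it stayed within the scatter. Compound 4 is therefore estimated to give 86% in this assay, with an expected range from 74% to 96%.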

Compound 4, largest response reached (reported as percent of maximum), in percent of the reference or control that the assay uses: 84%
Beside the measured number, compound 4's estimate is 2 percentage points above it, within the range that was stated.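

In this assay, isopropyl in place of hydrogen on an amide-type nitrogen gives a number 4 percentage points lower from compound 2 to compound 4 (within the scatter), so on the core of compound 2 this change again produces a step no larger than the usual scatter. Set beside the earlier step, the two cores do not separate: the same change on two cores in this assay, a number 2 percentage points lower (within the scatter) from compound 1 to compound 3 and a number 4 percentage points lower (within the scatter) from compound 2 to compound 4, 2 percentage points apart, within the scatter of two such steps. This shows that, for these two cores and this one read-out of largest response, the change carried over without a step beyond the scatter; it does not show that the same would hold on a third core, for another group at this nitrogen, or for any read-out other than largest response.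

The compounds shown leave open how a group other than isopropyl would read at this nitrogen, such as methyl, cyclopropyl or a longer chain. They also leave open what would happen if a carboxylic acid stood in place of the amide on either core.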